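A few compounds are considered here, and "the series" means these few. Any claim that something is new, unique, unknown or untested is made for them only; others in the source may bear on it.

Compound 2 `Cc1ccc(NC(=O)c2ccc(F)cc2)cc1-n1cc(-c2cnc3cccnn23)cn1` stands at a limit of the assay rather than at a number: in a functional assay on U-937 cells (Homo sapiens) for antiproliferative activity, read by CCK-8 assay, with a stated time of 24 h (a higher number here means a weaker inhibitor, a lower number a stronger inhibitor), compound 2 gives > 20000 nM. Compound 1 `Cc1ccc(NC(=O)c2ccc(C(F)(F)F)cc2)cc1-n1cc(-c2cnc3cccnn23)cn1` likewise sits at a limit in this assay, > 20000 nM. The step that the two limits leave unreadable from compound 1 to compound 2 is unreadable because both values lie at the limit of > 20000 nM in this assay, at which 2 of the 2 values shown sit. Compound 3 `Cc1ccc(NC(=O)c2ccc(CN3CCN(C)CC3)cc2)cc1-n1cc(-c2cnc3cccnn23)cn1` differs from compound 2 by (4-methylpiperazin-1-yl)methyl in place of fluoro on an aromatic carbon. No measured step bears on a change of this kind, and the one step shown gives no size or direction. Compound 3 is therefore expected to give about 15000 nM, with a range from 3000 nM to 60000 nM. The expected step from compound 2 to compound 3 is an at least 1.3-fold lower number from compound 2 to compound 3 (0.12 log units; that floor lies within the scatter).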

Compound 3, half-maximal inhibitory concentration: 10800 nM
For compound 3 the middle estimate is 1.4-fold (0.14 log units) above the measured one, and the stated range covers the measured number.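

In this assay, going by these compounds alone, (4-methylpiperazin-1-yl)methyl on this aromatic carbon, para to a large group, gives the first number rather than a limit. In place of fluoro it gives an at least 1.8-fold lower number from compound 2 to compound 3 (0.26 log units; that floor lies within the scatter), and in place of trifluoromethyl it gives an at least 1.8-fold lower number from compound 1 to compound 3 (0.26 log units; that floor lies within the scatter). Both steps are floors only, because their starting values are limits: the limit of > 20000 nM in this assay, at which 2 of the 3 values shown sit.

Still open, as far as these compounds go, is whether a morpholin-4-ylmethyl group, a dimethylaminomethyl group or a carboxylic acid at this place would also give a number. From the compounds shown here alone, the true size of the step also remains open.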